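A few compounds are considered here, and "the series" means these few. Any claim that something is new, unique, unknown or untested is made for them only; others in the source may bear on it.

Compound 1, `O=C1O[C@]2(CC[C@H](CNc3cnn(-c4ccccc4F)c3)CC2)CN1c1ccnnc1`: 0.2 nM
Compound 2, `O=C1O[C@]2(CC[C@H](CNc3ccc(C(F)(F)F)cn3)CC2)CN1c1ccccn1`: 1 nM
Compound 3, `O=C1O[C@]2(CC[C@H](CNc3ncc(-c4ccccc4F)cn3)CC2)CN1c1ccccn1`: 0.316 nM

Of the compounds shown here, three sharing one core have been measured in a functional assay for antagonist activity at Neuropeptide Y receptor type 5 (Homo sapiens); a higher number here means a weaker inhibitor, a lower number a stronger inhibitor. Compound 1 has the lowest of the three numbers; compound 3 is nearest to it and lies within the scatter, while compound 2 lies beyond it. The unmeasured compound 4, `O=C1O[C@]2(CC[C@H](CNc3cnn(-c4ccccc4F)c3)CC2)CN1c1cccnc1`, departs from compound 1 in one place: pyridin-3-yl in place of pyridazin-4-yl on an amide-type nitrogen in a ring. For the measured compounds named here, no step between measured compounds isolates this change, so the expectation rests on the spread of the three numbers alone. A small step, perhaps none beyond the scatter, is expected from compound 1 to compound 4, a 2.0-fold higher number from compound 1 to compound 4 (0.30 log units; within the scatter). In this assay compound 4 is therefore estimated at 0.4 nM, within a range from 0.12 nM to 1.5 nM.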

Compound 4, inhibition constant: 0.1 nM
Compound 4: the middle estimate sits 4.0-fold (0.60 log units) above what was measured; the measured number lies below the stated range.
By their numbers in this assay, from the lowest: compounds 4, 1 and 3 (each within the scatter of the next, the first and the last beyond it); then compound 2.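

In this assay, for the compounds shown here, the change at this position gives a 2.0-fold lower number from compound 1 to compound 4 (0.30 log units; within the scatter) and is the first single change that can be read here. With the core of compound 1 otherwise unchanged, losing one ring nitrogen and one hydrogen-bond acceptor from this ring leaves the number within the scatter, so pyridazin-4-yl is not needed for a sub-nanomolar value in this pair. No measurement given here explains this result.

As far as these compounds go, it remains open whether an unsubstituted phenyl ring, with no ring nitrogen, or a saturated piperidine ring would hold up on this nitrogen. From the compounds shown here alone, whether pyridin-3-yl behaves alike with other groups at the far end of the molecule also remains open.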